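A few compounds are considered here, and "the series" means these few. Any claim that something is new, unique, unknown or untested is made for them only; others in the source may bear on it.

Measured so far:
compound 1, `COc1cc(C(=O)N/N=C/c2ccc(F)c(F)c2)cc(OC)c1OC`: 35.1%
compound 2, `COc1cc(C2=NN(C(C)=O)C(c3cc(Cl)cc(Cl)c3)O2)cc(OC)c1OC`: 52.7%
compound 3, `COc1cc(/C=N/NC(=O)c2cc(OC)c(OC)c(OC)c2)cc(OC)c1OC`: 8.5%

In a functional assay on PC-3 cells (Homo sapiens) for antiproliferative activity, read by MTT assay, tested at 1 uM (a lower number here means a weaker effect, a higher number a stronger effect of the compound at the concentration tested), compound 1 stands second highest of the three numbers. Its nearest neighbour is compound 2, whose value of 52.7% lies higher by more than the usual scatter; furthest off is compound 3, whose 8.5% lies lower, again beyond the scatter. Compound 4 (`COc1cc(C(=O)N/N=C/c2ccccc2F)cc(OC)c1OC`) has not yet been measured. It differs from compound 1 in one place: 2-fluorophenyl in place of 3,4-difluorophenyl on a carbon with a double bond to nitrogen. From the compounds shown here alone, no comparable single change has been measured among the compounds here, so the size of this step is unknown; compound 4 is expected to stay close to compound 1, with a step of a number 5.1 percentage points lower from compound 1 to compound 4 (within the scatter) in this assay that would not exceed the scatter. Compound 4 is therefore estimated at 30%, within a range from 10% to 55%.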

Compound 4, a percentage reported as inhibition, at one concentration (the size of the read-out at that concentration, not a potency): 70.6%
Compound 4: middle estimate off by 40.6 percentage points, on the low side; measured number outside the range, above it.
By their numbers in this assay, from the lowest: compound 3; then compound 1; then compound 2; then compound 4.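

In this assay the group on the carbon with a double bond to nitrogen proves sensitive: 2-fluorophenyl in place of 3,4-difluorophenyl gives a number 35.5 percentage points higher from compound 1 to compound 4 (beyond the scatter) and so moves the read-out well past the scatter. This is the first single change that can be read among these compounds, and it shows that two fluorinated phenyl groups are not interchangeable at this place, although neither carries a hydrogen-bond donor, an acceptor or a net charge. Nothing at hand accounts for the size of this step. Still open, from the compounds shown here alone, is how unsubstituted phenyl, a chlorophenyl or an aminophenyl would read on the same carbon. Going by these compounds, it is also open whether the number follows the count of fluorine atoms or where they stand.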